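Methoxy in place of bromo: a small step expected

The source may hold more compounds than are shown below. What is called first, only, known or untested is meant among the compounds shown, and "the series" means these compounds.

Of the compounds shown here, two have numbers so far. In a functional assay on CNE-2 cells (Homo sapiens) for cytotoxicity, read by sulforhodamine B assay, with a stated time of 48 h (on this read-out lower numbers stand for stronger inhibition and higher numbers for weaker inhibition), compound 1 `O=C(/C=C/c1ccc(Br)cc1)c1cccc(-c2cccc(F)c2)c1` gives 10500 nM, and compound 2 `O=C(/C=C/c1cccc(-c2ccc(F)cc2)c1)c1ccc(O)cc1` gives 5510 nM. These two values lie within the usual scatter of each other, so compound 1 cannot be separated from compound 2 on the numbers shown. The two compounds differ in more than one place, so no measured single change is available as a guide.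

Compound 3 `COc1ccc(/C=C/C(=O)c2cccc(-c3cccc(F)c3)c2)cc1` keeps the core of compound 1 and alters one group, with methoxy in place of bromo on an aromatic carbon, para to a large group (methoxy in place of bromo on an aromatic carbon). The same difference reads 4-bromophenyl to 4-methoxyphenyl. On these data alone, its result in this assay is still open.

Among the measured compounds shown here, the data hold no direct precedent for this exchange, so the expectation rests only on the narrow spread between compound 2 at 5510 nM and compound 1 at 10500 nM. The step of a 1.4-fold lower number from compound 1 to compound 3 (0.15 log units; within the scatter) is expected to stay within the scatter, with no clear direction. For compound 3 the estimated value is 7500 nM, with an expected range from 2800 nM to 20000 nM.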

Compound 3, half-maximal inhibitory concentration: 740 nM
The estimate for compound 3 lay 10-fold (1.01 log units) above the measured number; measured number outside the range, below it.
By their numbers in this assay, from the lowest: compound 3; then compounds 2 and 1 (each within the scatter of the next).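

Among the compounds shown here, this exchange is the first change in one place with a measured result, since compounds 1 and 2 differ in more than one place and could not show what a single group contributes. In this assay, methoxy in place of bromo on this aromatic carbon, para to a large group, gives a 14-fold lower number from compound 1 to compound 3 (1.15 log units; beyond the scatter), so this position is sensitive to the group it carries and the change separates compound 3 from compound 1 well beyond repeat variation. No measurement at hand explains the size of this step.

A single exchange cannot show whether the lower number belongs to methoxy specifically or would also follow from other replacements of bromo, such as an ethoxy group, an amine or a chlorine atom in the same place. On these data alone, it also remains open whether methoxy in place of bromo would bring a step of similar size on a different core, or whether this step holds only for the core of compound 1.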